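The source may report more compounds than this note shows. Statements on the series, on what has been measured and on what is new or still open speak of the compounds shown alone.

Two compounds of the series carry numbers in a functional assay on MIA PaCa-2 cells (Homo sapiens) for antiproliferative activity, read by MTT assay, with a stated time of 72 h (a higher number here means that more compound is needed for the effect, a lower number that less compound is needed), so far. Compound 1 `Cc1nn(Cc2cccc(C(=O)NC(C)C)c2)c(C)c1NC(=O)c1ccc(COc2ccccc2)cc1` gives 8900 nM in this assay. Compound 2 `CNC(=O)c1cccc(Cn2nc(C)c(NC(=O)c3ccc(COc4ccc(C)cc4)cc3)c2C)c1` gives 2600 nM in this assay, the lower of the two numbers, and its gap to compound 1 lies beyond the usual scatter. Among the measured compounds shown here, compound 3 `CNC(=O)c1cccc(Cn2nc(C)c(NC(=O)c3ccc(COc4ccc(Cl)cc4)cc3)c2C)c1` is the next member to be measured; its single change is chloro in place of methyl on an aromatic carbon. For the measured compounds named here, no step of this kind between measured compounds is known, so the expectation rests on the change alone: the step of a 1.3-fold lower number from compound 2 to compound 3 (0.11 log units; within the scatter) is expected to stay within the scatter, with a slight lean toward a lower number. Compound 3 is estimated at 2000 nM, with a range from 800 nM to 5000 nM.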

Compound 3, half-maximal effective concentration: 4200 nM
For compound 3 the middle estimate is 2.1-fold (0.32 log units) below the measured one; low and high end bracket the measured number.
By their numbers in this assay, from the lowest: compounds 2 and 3 (each within the scatter of the next); then compound 1.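

In this assay, chloro in place of methyl on the aromatic carbon para to a large group gives a 1.6-fold higher number from compound 2 to compound 3 (0.21 log units; within the scatter). Among the compounds shown here, this single-place step is the first, and it does not separate 4-methylphenoxy from 4-chlorophenoxy in this read-out. No supporting data bear on this result.

The compounds shown leave open whether a methoxy group, a trifluoromethyl group or an amine at this position would give a step beyond the scatter. They also leave open how a substituent elsewhere on this ring would read.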